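A few compounds are considered here, and "the series" means these few. Any claim that something is new, unique, unknown or untested is made for them only; others in the source may bear on it.

Compound 1 `Nc1cccc(-c2cn3c(-c4ccccc4)csc3n2)c1`: 29000 nM
Compound 2 `C=C(Br)C(=O)Nc1cccc(-c2cn3c(-c4ccccc4)csc3n2)c1`: 2800 nM

Within the data shown here, in a functional assay on CCRF-CEM cells (Homo sapiens) for inhibition, read by cell counting, with a stated time of 3 days (a higher number here means a weaker inhibitor, a lower number a stronger inhibitor), compound 2 stands lowest of the two numbers, and the only measured step, a 10-fold lower number from compound 1 to compound 2 (1.02 log units; beyond the scatter), is large but concerns the amide end of the molecule. Compound 3 `C=C(Br)C(=O)Nc1cccc(-c2cn3c(-c4ccc(OC)cc4)csc3n2)c1` differs from compound 2 by methoxy in place of hydrogen on an aromatic carbon. Among the measured compounds shown here, no measured step touches this part of the shared core, so nothing here argues for a change beyond the scatter. Compound 3 is therefore expected to give about 2500 nM in this assay, within 900 nM to 7000 nM. The step this estimate implies, a 1.1-fold lower number from compound 2 to compound 3 (0.05 log units; within the scatter), is expected to stay inside the scatter.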

Compound 3, half-maximal inhibitory concentration: 500 nM
The estimate for compound 3 lay 5.0-fold (0.70 log units) above the measured number; measured number outside the range, below it.
By their numbers in this assay, from the lowest: compound 3; then compound 2; then compound 1.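

In this assay, the change from phenyl to 4-methoxyphenyl gives a 5.6-fold lower number from compound 2 to compound 3 (0.75 log units; beyond the scatter). Among these compounds, the number therefore responds to a change on this ring of the shared core, whereas the only earlier step, a 10-fold lower number from compound 1 to compound 2 (1.02 log units; beyond the scatter), concerned the amide end. Nothing available accounts for this shift.

The compounds shown leave open whether methoxy itself matters here, or whether a hydroxyl, an ethoxy or an amine in the same place would do the same. They also leave open whether methoxy lowers the number when the amide end carries a plain amine.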